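This account rests on a few compounds, and the source may have more. Where it says the series, first, only, none or still open, it means among the compounds named here.

Measured so far:
- compound 1, `CCN(CC)C(=O)c1ccccc1-c1ccc(CN2C(=O)[C@H](NC(=O)CC(C)(C)N)CCc3ccccc32)cc1`: 2 uM
- compound 2, `CC(C)(N)CC(=O)N[C@@H]1CCc2ccccc2N(Cc2ccc(-c3ccccc3C(=O)NCCCCO)cc2)C1=O`: 0.01 uM

In a functional assay (Pituitary gland cell) with Rattus norvegicus as the target (on this read-out lower numbers stand for an effect already at smaller amounts and higher numbers for an effect only at larger amounts of compound), compound 2 stands at the lowest of the two numbers; the nearest is compound 1, reached by a 200-fold lower number from compound 1 to compound 2 (2.30 log units; beyond the scatter). That single step exchanges the whole amide substituent, so it speaks for the amide part of the molecule mattering a great deal, but it does not separate the hydroxy from the rest of the chain.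

Compound 3, `CCCCCNC(=O)c1ccccc1-c1ccc(CN2C(=O)[C@H](NC(=O)CC(C)(C)N)CCc3ccccc32)cc1`, differs from compound 2 by methyl in place of hydroxy on a saturated chain carbon, four bonds along the chain from an amide-type nitrogen, so the chain keeps its length and only the hydroxy at its end is replaced. Among the measured compounds shown here, no measured step isolates this exchange; the large step from compound 1 to compound 2 only warns that changes here can be big. With nothing closer to lean on, a modest rise in this assay is expected, estimated as a 3.0-fold higher number from compound 2 to compound 3 (0.48 log units; beyond the scatter). For compound 3 the expected value is 0.03 uM, within 0.005 uM to 0.2 uM.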

Compound 3, concentration for half-maximal effect: > 1 uM
Compound 3 was reported as a limit; the forecaster's own chance of this, stated with the estimate: 5%; at least 33-fold (1.52 log units) between middle value and limit.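

Compound 3 is reported in this assay only as a limit: the limit of > 1 uM in this assay, at which 1 of the 3 values shown sits. Even so, replacing hydroxy with methyl on a saturated chain carbon, four bonds along the chain from an amide-type nitrogen, gives an at least 100-fold higher number from compound 2 to compound 3 (2.00 log units; beyond the scatter), so a chain of the same length without its hydroxy does not keep the low number of compound 2, and the hydroxy itself clearly matters, which the earlier change of the whole amide substituent could not separate. The step between compound 1 and compound 3 cannot be read against the limit.

Still open, as far as these compounds go, is whether another group at the chain end, such as an amine or a carboxylic acid, could take the place of the hydroxy. Also open, from the compounds shown here alone, is how a shorter or longer chain carrying the same hydroxy would compare with compound 2 at 0.01 uM.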